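Propoxy on the aromatic ring of a bicyclic pyridinyl diamine

This account rests on a few compounds, and the source may have more. Where it says the series, first, only, none or still open, it means among the compounds named here.

Measured compounds:
compound 1 `c1cncc(N2C[C@H]3CNC[C@H]3C2)c1` gives 0.12 nM
compound 2 `CN1C[C@@H]2CN(c3cccnc3)C[C@@H]2C1` gives 26 nM
compound 3 `Brc1ccc(N2C[C@H]3CNC[C@H]3C2)cn1` gives 0.28 nM

In an assay on membranes from brain for displacement of a labelled ligand from Neuronal acetylcholine receptor; alpha4/beta2 (Rattus norvegicus) (a lower number here means a stronger inhibitor, a higher number a weaker inhibitor), compound 1 has the lowest number of the three. Its nearest neighbour is compound 3, reached by the step of a 2.3-fold higher number from compound 1 to compound 3 (0.37 log units; beyond the scatter); its furthest is compound 2, reached by the step of a 220-fold higher number from compound 1 to compound 2 (2.34 log units; beyond the scatter). Compound 4 `CCCOc1cncc(N2C[C@H]3CNC[C@H]3C2)c1` is not yet measured. It differs from compound 1 by the change (propoxy in place of hydrogen on an aromatic carbon). Within the data shown here, of the two measured steps, only the one to compound 3 bears on this change, as it is also a replacement of hydrogen on an aromatic carbon, though at a different place and with a different group; that step was modest. The step to compound 2 touches the amine nitrogen of the core and does not bear on it. A modest rise is therefore expected, about a 2.5-fold higher number from compound 1 to compound 4 (0.40 log units; beyond the scatter). The estimate for compound 4 in this assay is 0.3 nM, with a range from 0.08 nM to 1.2 nM.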

Compound 4, inhibition constant: 0.041 nM
Compound 4: middle estimate off by 7.3-fold (0.86 log units), on the high side, and the stated range ends above it.
By their numbers in this assay, from the lowest: compound 4; then compound 1; then compound 3; then compound 2.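

In this assay, the aromatic carbon two atoms from the ring nitrogen accepts a propoxy chain with a gain rather than a loss, as a 2.9-fold lower number from compound 1 to compound 4 (0.47 log units; beyond the scatter) shows. The other aromatic replacement runs the opposite way, with a 2.3-fold higher number from compound 1 to compound 3 (0.37 log units; beyond the scatter), so replacing hydrogen on an aromatic carbon of this core does not have one fixed direction, although bromo and propoxy differ in both group and place. No supporting measurement accounts for the direction of either step.

Going by these compounds, whether a methoxy or butoxy group, or bromo itself, at this same carbon would give a lower or higher number remains open. On these data alone, it is also open whether propoxy would give a similar step on compound 2 , which carries methyl on the amine nitrogen.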